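This account rests on a few compounds, and the source may have more. Where it says the series, first, only, none or still open, it means among the compounds named here.

Compound 1 `COc1cc(OC)cc(-c2cc3ccccc3c(-c3cccc(OC)c3)n2)c1` and compound 2 `COc1cc(OC)cc(-c2cc3ccccc3c(-c3cccc(N)c3)n2)c1` share one core, and compound 3 `COc1cccc(-c2nc(-c3ccc(OC)c(OC)c3)cc3cc(C)ccc23)c1` carries a second core; how the two cores differ is not broken down here. In a functional assay on T47D cells (Homo sapiens) for cytotoxicity, read by CCK-8 assay and cell counting, with a stated time of 72 h (a higher number here means a weaker inhibitor, a lower number a stronger inhibitor), compound 1 gives 1120 nM, and compound 2 gives 980 nM. The change between them, (amino in place of methoxy on an aromatic carbon), made a step of a 1.1-fold lower number from compound 1 to compound 2 (0.06 log units; within the scatter). In this assay compound 3 gives 7860 nM, the highest number of the three, with both other compounds sitting at lower numbers beyond the usual scatter. Compound 4 `COc1ccc(-c2cc3cc(C)ccc3c(-c3cccc(N)c3)n2)cc1OC` is still unmeasured; it differs from compound 3 by amino in place of methoxy on an aromatic carbon, and since the place of the change reads the same in both pairs, this is the same change that turned compound 1 into compound 2. Because that earlier step of a 1.1-fold lower number from compound 1 to compound 2 (0.06 log units; within the scatter) stayed within the scatter, the step from compound 3 to compound 4 is expected to be of similar size, about a 1.1-fold lower number from compound 3 to compound 4 (0.05 log units; within the scatter), resting on one prior example only. On this basis compound 4 is estimated to give about 7000 nM in this assay, between 3000 nM and 16000 nM.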

Compound 4, half-maximal inhibitory concentration: 450 nM
Compound 4: middle estimate off by 16-fold (1.19 log units), on the high side; the measured number lies below the stated range.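

In this assay, amino in place of methoxy gave a 17-fold lower number from compound 3 to compound 4 (1.24 log units; beyond the scatter), a large step, while the same change on the core of compound 1 stayed within the scatter, and the two steps differ: the same change on two cores in this assay, a 1.1-fold lower number (0.06 log units; within the scatter) from compound 1 to compound 2 and a 17-fold lower number (1.24 log units; beyond the scatter) from compound 3 to compound 4, 15-fold (1.18 log units) apart, beyond the scatter of two such steps

This shows that the size of the step did not carry from one core to the other, so the result on the core of compound 1 was no safe guide to the result on the core of compound 3. It does not show which structural difference between the two cores lies behind the gap, nor how the change would behave on any further core, since the comparison rests on just two pairs of compounds.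

The compounds shown leave open whether a hydroxyl, a methylamino group or an acetamide in place of the methoxy would give a similarly large step on the core of compound 3. They also leave open whether the step from the 3-methoxyphenyl to the 3-aminophenyl compound would persist in other cell lines.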